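Ring Size on the Side Chain and Cell Toxicity

The compounds below may be only part of what the source reports. "The series", "measured", "known", "first", "only" and "open" are said of these compounds alone.

Compound 1 `CC(C)C[C@H](NC(=O)/C=C/c1ccccc1)C(=O)N[C@@H](C[C@@H]1CCNC1=O)C(=O)C(=O)NCc1ccccc1` gives, in an ADME assay on Huh-7 cells (Homo sapiens) for cytotoxicity, with a stated time of 2 days (on this read-out higher numbers stand for lower toxicity in this test and lower numbers for higher toxicity in this test), a value that is a limit of the measurement: > 188000 nM.
Compound 2 `O=C(/C=C/c1ccccc1)N[C@@H](CC1CCCCC1)C(=O)N[C@@H](C[C@@H]1CCNC1=O)C(=O)C(=O)NCc1ccccc1` gives in this assay 43000 nM.
Compound 3 `O=C(/C=C/c1ccccc1)N[C@@H](CC1CCC1)C(=O)N[C@@H](C[C@@H]1CCNC1=O)C(=O)C(=O)NCc1ccccc1` gives in this assay 124000 nM.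

Among the two numbers that are not limits, compound 3 holds the higher one; its nearest neighbour is compound 2, and the difference is a 2.9-fold higher number from compound 2 to compound 3 (0.46 log units; beyond the scatter). The value of compound 1 is only a limit of > 188000 nM in this assay, at which 1 of the 3 values shown sits, and gives no number to rank.

Compound 4 `O=C(/C=C/c1ccccc1)N[C@@H](CC1CCCC1)C(=O)N[C@@H](C[C@@H]1CCNC1=O)C(=O)C(=O)NCc1ccccc1` differs from compound 3 in one place: cyclopentyl in place of cyclobutyl on a saturated chain carbon, two bonds along the chain from an amide-type nitrogen and a carbonyl carbon. The measured steps that touch the same position are the change from isopropyl to cyclohexyl, an at least 4.3-fold lower number from compound 1 to compound 2 (0.64 log units; beyond the scatter), from isopropyl to cyclobutyl, an at least 1.5-fold lower number from compound 1 to compound 3 (0.18 log units; that floor lies within the scatter), and from cyclohexyl to cyclobutyl, a 2.9-fold higher number from compound 2 to compound 3 (0.46 log units; beyond the scatter). Cyclopentyl stands between cyclobutyl and cyclohexyl in this short series, so compound 4 is expected to land between compound 3 and compound 2, with a modest lowering of the number, estimated as a 1.7-fold lower number from compound 3 to compound 4 (0.22 log units; within the scatter). The estimate for compound 4 in this assay is 75000 nM, with a range from 40000 nM to 135000 nM.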

Compound 4, half-maximal cytotoxic concentration: 47500 nM
For compound 4 the middle estimate is 1.6-fold (0.20 log units) above the measured one; measured number inside the range.
By their numbers in this assay, from the lowest: compounds 2 and 4 (each within the scatter of the next); then compound 3. At a limit, above all of these: compound 1.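

In this assay, where a lower number means more toxicity to the cells, going from the four-membered ring to the five-membered ring gives a 2.6-fold lower number from compound 3 to compound 4 (0.42 log units; beyond the scatter) and that is a real change, whereas compound 2 and compound 4 stay level, with a 1.1-fold higher number from compound 2 to compound 4 (0.04 log units; within the scatter) inside the usual scatter. At this position, then, the number does not fall evenly as the ring grows: cyclobutyl stands apart from both larger rings, and cyclopentyl already matches cyclohexyl. Replacing the open isopropyl group with cyclopentyl gives an at least 3.9-fold lower number from compound 1 to compound 4 (0.59 log units; beyond the scatter) as a floor and not a full size, since the value of compound 1 is a limit and not a number: the limit of > 188000 nM in this assay, at which 1 of the 4 values shown sits.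

The compounds shown leave open whether the number stays level with a still larger ring such as cycloheptyl, or with a flat phenyl ring or a longer open chain at the same place. They also cannot tell what happens when one of these rings carries an amine or a carboxylic acid, or why the number changes from cyclobutyl to cyclopentyl and then stops changing.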